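The compounds below may be only part of what the source reports. "The series", "measured", "known", "first", "only" and "open" are said of these compounds alone.

Working notes on the series

The shared core carries a four-carbon side chain bearing an oxygen on a saturated carbon; the group on that carbon varies. Compound 1 `C[C@@H](O)CCn1nc2c(Br)c(Br)c(Br)c(Br)c2n1` carries a methyl there, and in a functional assay on MCF7 cells (Homo sapiens) for antiproliferative activity, read by MTT assay, with a stated time of 24 h, tested at 50 uM (a higher number here means a weaker effect of the compound at the concentration tested, a lower number a stronger effect), compound 1 gives 102%. Among the compounds with values here, compound 2 `OC(CCn1nc2c(Br)c(Br)c(Br)c(Br)c2n1)c1cccc(Cl)c1` carries a 3-chlorophenyl on the same carbon, and in this assay compound 2 gives 28%, the lowest of the two numbers so far; the gap to compound 1 lies beyond the scatter, so compound 2 shows the stronger effect of the pair.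

Compound 3 `OC(CCn1nc2c(Br)c(Br)c(Br)c(Br)c2n1)c1ccc(F)cc1` is the next member. It differs from compound 2 as follows: 4-fluorophenyl in place of 3-chlorophenyl on a saturated chain carbon bound to an oxygen on a saturated carbon and a saturated chain carbon. Within the data shown here, no measured pair shows a step of this kind, so the size of the step from compound 2 to compound 3 in this assay is an open question. A phenyl group stays in place, and the expectation is a modest weakening, estimated as a number 17 percentage points higher from compound 2 to compound 3 (beyond the scatter). Compound 3 is therefore expected to give about 45% in this assay, with a range from 25% to 70%.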

Compound 3, a percentage reported as activity, at one concentration (the size of the read-out at that concentration, not a potency): 16%
Estimate against measurement, compound 3: 29 percentage points above; the whole stated range lies above it.
By their numbers in this assay, from the lowest: compound 3; then compound 2; then compound 1.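

The aryl group on this carbon is not tied to 3-chlorophenyl: 4-fluorophenyl in its place brings a number 12 percentage points lower from compound 2 to compound 3 (beyond the scatter) in this assay, so the low reading of compound 2 is not unique to that group. The step is modest, but it shows that this position responds to the aryl substituent as well as to the methyl-to-aryl change seen earlier. The halogen and its ring position change together in this single step, and neither can be credited separately. No measured property of these compounds bears on the step.

Unsubstituted phenyl and 4-chlorophenyl remain open, and either could begin to separate the halogen from its ring position. Also open, from the compounds shown here alone, is how an amine or a carboxylic acid on the ring, or a longer chain, would read here.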